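Benzyl for isopentyl on the ring amide nitrogen

The source may report more compounds than this note shows. Statements on the series, on what has been measured and on what is new or still open speak of the compounds shown alone.

Among the compounds with values here, compound 1 `CC(C)CCN1C(=O)C(C2=NS(=O)(=O)c3cc(NS(C)(=O)=O)ccc3N2)=C(O)C2CCCC21` is the one member of the series with an actual number in an in vitro ADME assay on microsomes from liver (Homo sapiens) for metabolic stability; a lower number here means that the compound disappears faster, a higher number that the compound lasts longer: compound 1 gives 0.167 h. Compound 2 `CS(=O)(=O)Nc1ccc2c(c1)S(=O)(=O)N=C(C1=C(O)[C@H]3CCC[C@H]3N(CC3CC3)C1=O)N2` reaches only the limit of this assay, reported as > 1 h. Compound 3 `Cc1cc(CN2C(=O)C(C3=NS(=O)(=O)c4cc(NS(C)(=O)=O)ccc4N3)=C(O)[C@H]3CCC[C@H]32)ccc1F` likewise sits at the limit, reported as > 1 h. Between those two lies the step that the two limits leave unreadable from compound 2 to compound 3, which the two limits leave unreadable. Compound 4 `CS(=O)(=O)Nc1ccc2c(c1)S(=O)(=O)N=C(C1=C(O)C3CCCC3N(Cc3ccccc3)C1=O)N2` has not yet been measured in this assay. Its change from compound 1 is phenyl in place of isobutyl on a saturated chain carbon bound to an amide-type nitrogen in a ring; cut one bond further out, this reads isopentyl to benzyl. Within the data shown here, no measured step covers exactly this exchange. What bears on it is that the two measured compounds carrying a ring on that chain carbon, compound 2 and compound 3, both stand at the limit of > 1 h in this assay, at which 2 of the 3 values shown sit, whereas compound 1 with its open chain falls well short of that mark. The step from compound 1 to compound 4 is therefore expected to be large and towards a longer half-life, with a fair chance that compound 4 is itself reported only as a limit. Compound 4 is estimated at 1.2 h, within 0.4 h to 3 h, the expected step being a 7.2-fold higher number from compound 1 to compound 4 (0.86 log units; beyond the scatter).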

Compound 4, half-life: 0.833 h
The estimate for compound 4 lay 1.4-fold (0.16 log units) above the measured number, and the stated range covers the measured number.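

Phenyl in place of isobutyl on a saturated chain carbon bound to an amide-type nitrogen in a ring gives a 5.0-fold higher number from compound 1 to compound 4 (0.70 log units; beyond the scatter) in this assay, so this position has a readable effect on the half-life. Within the data shown here, this is the first step at this position with a size, since the step between the two limits cannot be read. Compound 2 and compound 3 remain limits, so the aromatic ring of compound 4 is the only ring here with an actual number, and the upper end of the series stays unresolved: the limit of > 1 h in this assay, at which 2 of the 4 values shown sit.

The compounds shown do not separate the effect of the aromatic ring from the loss of the branched open chain, and cyclohexyl or a plain propyl group on the same chain carbon would address that directly. From the compounds shown here alone, it also remains open how a substituent on the phenyl ring of compound 4, such as a fluorine or a methyl group, or an amine on the chain, would shift the half-life, and whether the series can be ranked beyond the limit at all.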